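The compounds below may be only part of what the source reports. "The series", "measured", "known", "first", "only" and "open" are said of these compounds alone.

Compound 1 `Cc1cc(NCc2nccn2C)n2nc(C)c(-c3ccccc3)c2n1` — 26900 nM
Compound 2 `Cc1cc(NCc2ccccn2)n2ncc(-c3ccncc3)c2n1` — 161000 nM
Compound 3 `Cc1cc(NCc2nccn2C)n2nc(C)cc2n1` — 182000 nM

In a physicochemical assay for solubility, read by HPLC, using the shake flask method, measured as kinetic solubility, with a stated time of 2 h, at pH 7.4 (on this read-out lower numbers stand for lower solubility and higher numbers for higher solubility), compound 1 stands lowest of the three numbers; compound 2 and compound 3 both lie well above it, and the step of a 6.8-fold higher number from compound 1 to compound 3 (0.83 log units; beyond the scatter) shows how far hydrogen in place of phenyl moves the read-out. Compound 4 `Cc1cc(NCc2ncnn2C)n2nc(C)c(-c3ccccc3)c2n1` differs from compound 1 by 1-methyl-1H-1,2,4-triazol-5-yl in place of 1-methyl-1H-imidazol-2-yl on a saturated chain carbon bound to a nitrogen on an aromatic ring. For the measured compounds named here, no measured step bears on this change: the only step measured exchanges the phenyl, not the five-membered ring, so nothing here tells how far the triazolyl ring in place of the imidazolyl ring shifts the read-out. The expectation is therefore a small rise, a 1.5-fold higher number from compound 1 to compound 4 (0.17 log units; within the scatter), close to the scatter. Compound 4 is estimated at 40000 nM, with a range from 15000 nM to 110000 nM.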

Compound 4, solubility: 185000 nM
Compound 4: the middle estimate sits 4.6-fold (0.67 log units) below what was measured; the whole stated range lies below it.
By their numbers in this assay, from the lowest: compound 1; then compounds 2, 3 and 4 (each within the scatter of the next).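

In this assay, the saturated chain carbon bound to a nitrogen on an aromatic ring proves to be a place where a single exchange moves the read-out while the phenyl stays: 1-methyl-1H-1,2,4-triazol-5-yl in place of 1-methyl-1H-imidazol-2-yl gives a 6.9-fold higher number from compound 1 to compound 4 (0.84 log units; beyond the scatter). For the compounds shown here, the phenyl is therefore not the only place where one change takes compound 1 beyond the scatter. No measurement here explains this rise. From the compounds shown here alone, whether the same ring exchange does as much without the phenyl stays open, as does what an amine or a carboxylic acid would do in this place.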